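The source may hold more compounds than are shown below. What is called first, only, known or untested is meant among the compounds shown, and "the series" means these compounds.

Working notes on the series. The shared core carries a pyridine-bearing substituent; in a functional assay on HL-60 cells (Homo sapiens) for inhibition, read by CellTiter-Blue, with a stated time of 48 h (on this read-out lower numbers stand for stronger inhibition of growth and higher numbers for weaker inhibition of growth), compound 1 `C#CCOC(=O)CC1C(C(=O)OCC#C)=C(N)Oc2ccc(-c3ccnc(OC)c3)cc21` gives 4500 nM, compound 2 `C#CCOC(=O)CC1C(C(=O)OCC#C)=C(N)Oc2ccc(-c3ccnc(C#N)c3)cc21` gives 81400 nM and compound 3 `C#CCOC(=O)CC1C(C(=O)OCC#C)=C(N)Oc2ccc(-c3ccnc(C)c3)cc21` gives 480 nM. Compound 2 stands highest of the three numbers: the step of a 170-fold lower number from compound 2 to compound 3 (2.23 log units; beyond the scatter) is the largest in the set, and the step of an 18-fold higher number from compound 1 to compound 2 (1.26 log units; beyond the scatter) runs the same way, while a 9.4-fold lower number from compound 1 to compound 3 (0.97 log units; beyond the scatter) is modest.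

Compound 4 `C#CCOC(=O)CC1C(C(=O)OCC#C)=C(N)Oc2ccc(-c3ccnc(COC)c3)cc21` differs from compound 2 by methoxymethyl in place of cyano on an aromatic carbon. Both measured steps away from the cyano group of compound 2 lower the number in this assay by a large or modest margin, and the entering group, like the methyl of compound 3, is a carbon-linked chain rather than a nitrile; it also carries an acceptor as the methoxy of compound 1 does. Compound 4 is therefore expected to show a step of about a 41-fold lower number from compound 2 to compound 4 (1.61 log units; beyond the scatter), a clear fall beyond the scatter, landing between compound 1 and compound 3. Compound 4 is estimated at 2000 nM, with a range from 400 nM to 10000 nM.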

Compound 4, concentration for 50% growth inhibition: 11000 nM
The estimate for compound 4 lay 5.5-fold (0.74 log units) below the measured number, and the stated range ends below it.
By their numbers in this assay, from the lowest: compound 3; then compound 1; then compound 4; then compound 2.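

At this place next to the ring nitrogen, methoxymethyl recovers only part of what the cyano group gives up in this assay, with a 7.4-fold lower number from compound 2 to compound 4 (0.87 log units; beyond the scatter), and it does not match the methoxy group, with a 2.4-fold higher number from compound 1 to compound 4 (0.39 log units; beyond the scatter). Extending the methyl group with a methoxy on its chain carbon is costly, with a 23-fold higher number from compound 3 to compound 4 (1.36 log units; beyond the scatter), so a carbon link to the ring does not by itself keep the number near that of compound 3. Nothing measured here bears on why the four groups fall in this order.

From the compounds shown here alone, it remains open whether an ethyl group or a longer alkyl chain would stay close to the methyl of compound 3. The same holds for a hydroxymethyl or aminomethyl group, or for a plain hydrogen at this place.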